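The source may report more compounds than this note shows. Statements on the series, on what has been measured and on what is new or still open speak of the compounds shown alone.

Working notes on the series.

All three measured compounds share one core and differ only in the aryl group on a double-bonded chain carbon bound to a double-bonded chain carbon. In a functional assay on HT-29 cells (Homo sapiens) for inhibition, read by MTT assay, with a stated time of 48 h (on this read-out lower numbers stand for stronger inhibition and higher numbers for weaker inhibition), compound 1 `COc1cc(/C=C/c2ccc(NC(=O)/C=C/c3ccc([N+](=O)[O-])cc3)cc2)cc(OC)c1` gives 10700 nM; compound 2 `COc1cc(/C=C/c2ccc(NC(=O)/C=C/c3ccc(F)cc3F)cc2)cc(OC)c1` gives 18100 nM; compound 3 `COc1cc(/C=C/c2ccc(NC(=O)/C=C/c3ccccn3)cc2)cc(OC)c1` gives 6120 nM. The steps between them are a 1.7-fold higher number from compound 1 to compound 2 (0.23 log units; within the scatter), a 1.7-fold lower number from compound 1 to compound 3 (0.24 log units; within the scatter) and a 3.0-fold lower number from compound 2 to compound 3 (0.47 log units; beyond the scatter). Compound 3 thus shows the lowest number of the three, though its gap to compound 1 is within the scatter and only its gap to compound 2 lies beyond it.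

Compound 4 `COc1cc(/C=C/c2ccc(NC(=O)/C=C/c3ccc(O)c(O)c3)cc2)cc(OC)c1` is not yet measured. The change from compound 3 is 3,4-dihydroxyphenyl in place of pyridin-2-yl on a double-bonded chain carbon bound to a double-bonded chain carbon. For the measured compounds named here, no measured step involves the entering group, so the only guide is that exchanges of the aryl group at this place have moved this assay between a step within the scatter and a modest one. A step of that order, or none beyond the scatter, is therefore expected. The step expected here is a 1.1-fold higher number from compound 3 to compound 4 (0.06 log units; within the scatter). For compound 4 the estimate in this assay is 7000 nM, with a range from 2500 nM to 20000 nM.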

Compound 4, half-maximal inhibitory concentration: 1560 nM
Estimate against measurement, compound 4: 4.5-fold (0.65 log units) above; measured number outside the range, below it.
By their numbers in this assay, from the lowest: compound 4; then compounds 3, 1 and 2 (each within the scatter of the next, the first and the last beyond it).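

In this assay, for the compounds shown here, the 3,4-dihydroxyphenyl group brings a 3.9-fold lower number from compound 3 to compound 4 (0.59 log units; beyond the scatter) and a 6.9-fold lower number from compound 1 to compound 4 (0.84 log units; beyond the scatter) and also a 12-fold lower number from compound 2 to compound 4 (1.06 log units; beyond the scatter) as the only large step at this place. Going by these compounds alone, compound 4 is thus the strongest of the four and the only one whose steps to all the others lie beyond the scatter, so exchanges of the aryl group here can move the number further than the earlier compounds showed. Unlike pyridin-2-yl, the entering group carries hydrogen-bond donors, but one compound cannot tie the lower number to them.

Still open, on these data alone, is whether both hydroxyl groups are needed, and what a single hydroxyl group, two methoxy groups or an amine would give at this place. No measurement shown gives a reason for the lower number of compound 4.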